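The source may hold more compounds than are shown below. What is called first, only, known or untested is meant among the compounds shown, and "the series" means these compounds.

Of the compounds shown here, two have been measured in a functional assay on MCF7 cells (Homo sapiens) for inhibition; on this read-out higher numbers stand for weaker inhibition and lower numbers for stronger inhibition. Compound 1 `CCn1c(=O)/c(=C2\Sc3ccccc3N2C)s/c1=C\c1ccncc1Nc1ccccc1C` gives 990 nM. Compound 2 `CCn1c(=O)/c(=C2\Sc3ccc(OC)cc3N2C)s/c1=C\c1ccncc1Nc1ccccc1C` gives 420 nM in this assay. Going by the values given here, the only measured change between them is a 2.4-fold lower number from compound 1 to compound 2 (0.37 log units; beyond the scatter). Compound 2 therefore holds the lowest of the two numbers, with compound 1 the nearest to it.

Compound 3 `CCn1c(=O)/c(=C2\Sc3ccc(C)cc3N2C)s/c1=C\c1ccncc1Nc1ccccc1C` has not yet been measured. It differs from compound 2 in one place: methyl in place of methoxy on an aromatic carbon. Among the compounds with values here, the single measured step that concerns this position is a 2.4-fold lower number from compound 1 to compound 2 (0.37 log units; beyond the scatter), in which a methoxy took the place of a hydrogen. Within the data shown here, no measured step shows a methyl at this position, so it is open whether the methyl will act more like the methoxy or more like the bare hydrogen. The expected step is a 1.4-fold higher number from compound 2 to compound 3 (0.15 log units; within the scatter), a partial return in the direction of the unsubstituted compound, small enough that it may not rise beyond the scatter. Compound 3 is therefore expected to give about 600 nM in this assay, with a likely range from 300 nM to 1200 nM.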

Compound 3, half-maximal inhibitory concentration: 400 nM
Compound 3: middle estimate off by 1.5-fold (0.18 log units), on the high side, and the stated range covers the measured number.
By their numbers in this assay, from the lowest: compounds 3 and 2 (each within the scatter of the next); then compound 1.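

In this assay, putting methyl in place of methoxy on this aromatic carbon, which lies para to a fused ring, leaves the number within the usual scatter (a 1.1-fold lower number from compound 2 to compound 3 (0.02 log units; within the scatter)), so the two groups cannot be told apart on this read-out. Compared with the bare hydrogen of compound 1, the methyl gives a modest step beyond the scatter (a 2.5-fold lower number from compound 1 to compound 3 (0.39 log units; beyond the scatter)), much like the one methoxy gave, which shows that the gain seen earlier does not need the oxygen of the methoxy: a group of one carbon, counted with no hydrogen-bond acceptor, reaches the same level in these compounds. Nothing measured here accounts for the two groups reading alike, so the result describes what happens at this position without explaining it.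

The compounds shown leave open how far this tolerance extends, since a halogen such as chlorine, an amine, a carboxylic acid or a longer chain such as ethyl could each behave differently on this carbon. They also leave open whether methyl or methoxy would give a similar step on any other carbon of the same ring, because every change shown sits at this one place on the shared core.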